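The source may hold more compounds than are shown below. What is called first, only, known or untested is meant among the compounds shown, and "the series" means these compounds.

Three compounds sharing one core were run in an ADME assay on microsomes from liver (Homo sapiens) for metabolic stability, read by LC-MS, using NADPH, with a stated time of 30 min, tested at 0.1 uM; a lower number here means that less of the compound is left, a higher number that more of the compound is left. Compound 1 `C[C@@]1(c2cc(NC(=O)c3coc(C(F)F)n3)ccc2F)C=C(CF)OC(N)=N1` gives 84% in this assay, the highest of the three numbers shown, though its neighbours sit within the scatter of it. Compound 3 `COc1cnc(C(=O)Nc2ccc(F)c([C@]3(C)C=C(CF)OC(N)=N3)c2)cn1` gives 80%, and compound 2 `C[C@@]1(c2cc(NC(=O)c3coc(CF)n3)ccc2F)C=C(CF)OC(N)=N1` gives 76%. The step of a number 4 percentage points lower from compound 1 to compound 3 (within the scatter) and the step of a number 4 percentage points higher from compound 2 to compound 3 (within the scatter) each come from exchanging the group on the carbonyl carbon, while a number 8 percentage points lower from compound 1 to compound 2 (within the scatter) comes from the fluoromethyl chain; none of the three exceeds the scatter.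

Compound 4 `C[C@@]1(c2cc(NC(=O)c3ncc(C#N)cc3Cl)ccc2F)C=C(CF)OC(N)=N1` has not yet been measured. It differs from compound 1 in this way: 3-chloro-5-cyanopyridin-2-yl in place of 2-(difluoromethyl)-1,3-oxazol-4-yl on a carbonyl carbon. Among the compounds with values here, the two measured exchanges on the carbonyl carbon are the steps that bear on it, and both stayed within the scatter. A step of the same modest kind is therefore expected, a number 4 percentage points lower from compound 1 to compound 4 (within the scatter), in no direction that would exceed the scatter. Compound 4 is estimated to give 80% in this assay, with a range from 66% to 92%.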

Compound 4, percent of the compound remaining: 57%
Estimate against measurement, compound 4: 23 percentage points above, and the stated range ends above it.
By their numbers in this assay, from the lowest: compound 4; then compounds 2, 3 and 1 (each within the scatter of the next).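

In this assay the group on the carbonyl carbon proved able to move the number beyond the scatter: the exchange for 3-chloro-5-cyanopyridin-2-yl gives a number 27 percentage points lower from compound 1 to compound 4 (beyond the scatter) and gives a number 23 percentage points lower from compound 3 to compound 4 (beyond the scatter) and also a number 19 percentage points lower from compound 2 to compound 4 (beyond the scatter) in the same direction. The exchanges among the two oxazolyl groups and 5-methoxypyrazin-2-yl had stayed within the scatter, so this place on the shared core is not indifferent to every group, and compound 4 alone stands apart from the other three. No measurement shown here accounts for this difference.

The compounds shown leave open whether the chlorine, the nitrile or the pyridine ring itself goes with the lower number. A 3-chloropyridin-2-yl or a 5-cyanopyridin-2-yl group on the carbonyl carbon would separate these, but neither stands among them.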